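A few compounds are considered here, and "the series" means these few. Any claim that something is new, unique, unknown or untested is made for them only; others in the source may bear on it.

Measured so far in a functional assay on DU-145 cells (Homo sapiens) for inhibition, read by sulforhodamine B assay, with a stated time of 48 h; a higher number here means that more compound is tolerated, a lower number that less compound is tolerated:
- compound 1, `COc1cc(-c2nn(-c3cccc(NC(=O)Nc4cc(C(F)(F)F)cc(C(F)(F)F)c4)c3)cc2-c2ccncc2)ccc1Cl`: 21100 nM
- compound 2, `COc1cc(-c2nn(-c3cccc(NC(=O)Nc4ccc(Cl)c(Cl)c4)c3)cc2-c2ccncc2)ccc1Cl`: > 50000 nM
- compound 3, `O=C(Nc1cccc(-n2cc(-c3ccncc3)c(-c3ccc(Cl)c(O)c3)n2)c1)Nc1ccc(Cl)c(Cl)c1`: > 32500 nM

Compound 1 is the only one of the three with a number; in this assay compound 1 gives 21100 nM. Compound 2 gives only a limit of this assay, > 50000 nM. Compound 3 likewise gives only a limit, > 32500 nM. The difference between the core of compound 1 and the core of compound 2 is not broken down here.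

Compound 3 arises from compound 2 by hydrogen in place of methyl on an oxygen on an aromatic ring. The resulting step, a step that the two limits leave unreadable from compound 2 to compound 3, cannot be sized because compound 2 sits at the limit of > 50000 nM in this assay, at which 1 of the 3 values shown sits. Compound 3 in turn sits at the limit of > 32500 nM in this assay, at which 1 of the 3 values shown sits.

Compound 4, `O=C(Nc1cccc(-n2cc(-c3ccncc3)c(-c3ccc(Cl)c(O)c3)n2)c1)Nc1cc(C(F)(F)F)cc(C(F)(F)F)c1`, is not yet measured. It arises from compound 1 by the same change, (hydrogen in place of methyl on an oxygen on an aromatic ring), the place being described in the same words in both pairs. Within the data shown here, since the one measured example of this change yields no readable step, the expectation for compound 4 rests on compound 1 alone, whose value is 21100 nM. The expected step is a 1.2-fold higher number from compound 1 to compound 4 (0.07 log units; within the scatter). Compound 4 is therefore estimated at 25000 nM, between 10000 nM and 60000 nM.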

Compound 4, concentration lethal to 50% of the cells: 17400 nM
The estimate for compound 4 lay 1.4-fold (0.16 log units) above the measured number; measured number inside the range.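

In this assay replacing the 4-chloro-3-methoxyphenyl group by 4-chloro-3-hydroxyphenyl gives a 1.2-fold lower number from compound 1 to compound 4 (0.08 log units; within the scatter) so on the core of compound 1 the two values cannot be told apart, and methoxy and hydroxy read alike here. The same change on the other core, from compound 2 to compound 3, cannot be read, as both compounds carry only limits of the assay, so this single readable pair shows no rule for carrying the change from one core to another. Nothing measured here speaks to why the values of this pair stay so close.

The compounds shown hold only methoxy or hydroxy at this place on the ring, so it remains open how an amine, a carboxylic acid or a longer chain such as ethoxy would read there. Going by these compounds, every value comes from this assay and how the change reads in any other test also stays open.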